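This account rests on a few compounds, and the source may have more. Where it says the series, first, only, none or still open, it means among the compounds named here.

Working notes on the series. Compound 1 `COc1ccc(-c2nc3ccccn3c2C(=O)/C=C\Nc2ccc3[nH]ccc3c2)cc1` carries 1H-indol-5-yl on the amine nitrogen and a 4-methoxyphenyl group on the shared core. In a functional assay on MCF7 cells (Homo sapiens) for cytotoxicity, read by MTT assay, with a stated time of 48 h (a lower number here means a stronger inhibitor, a higher number a weaker inhibitor), compound 1 gives 18900 nM. Compound 2 `COc1ccc(-c2nc3ccccn3c2C(=O)/C=C\Nc2ccc3cc[nH]c3c2)cc1` carries 1H-indol-6-yl in place of 1H-indol-5-yl on the amine nitrogen, and in this assay compound 2 gives 19400 nM; the step of a 1.0-fold higher number from compound 1 to compound 2 (0.01 log units; within the scatter) is within the scatter. Compound 1 thus stands at one of two numbers that lie within the scatter of each other, and no ranking of the two is supported.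

Compound 3 `O=C(/C=C\Nc1ccc2[nH]ccc2c1)c1c(-c2ccc(Cl)cc2)nc2ccccn12` differs from compound 1 in one place: chloro in place of methoxy on an aromatic carbon. Within the data shown here, no measured step touches this change. Among the measured compounds shown here, the only measured step, a 1.0-fold higher number from compound 1 to compound 2 (0.01 log units; within the scatter), concerns the group on the amine nitrogen and leaves the 4-methoxyphenyl group unchanged. For the measured compounds named here, the two measured compounds therefore offer no pointer to a step in this assay in either direction, and the expectation is for a step not beyond the scatter, a 1.0-fold higher number from compound 1 to compound 3 (0.00 log units; within the scatter). Going by the values given here, compound 3 is accordingly estimated at 19000 nM, with a range from 6000 nM to 60000 nM; the range is set wide, since the change has no measured counterpart.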

Compound 3, half-maximal inhibitory concentration: 7130 nM
Estimate against measurement, compound 3: 2.7-fold (0.43 log units) above; the measured number falls inside the stated range.
By their numbers in this assay, from the lowest: compound 3; then compounds 1 and 2 (each within the scatter of the next).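

In this assay the position para to a large group on the six-membered aromatic ring of carbon only now has a measured step, and chloro in place of methoxy there gives a 2.7-fold lower number from compound 1 to compound 3 (0.42 log units; beyond the scatter) as a modest change beyond the scatter. Among these compounds, the earlier step of a 1.0-fold higher number from compound 1 to compound 2 (0.01 log units; within the scatter) stayed within the scatter and left this position untouched, so the pair of compound 1 and compound 3 is the only evidence that the number moves with the change from 4-methoxyphenyl to 4-chlorophenyl, and it holds for 1H-indol-5-yl on the amine nitrogen alone. Nothing at hand accounts for this step.

From the compounds shown here alone, whether the same change would give a similar step with the 1H-indol-6-yl group of compound 2 remains open. Also open, going by these compounds, is how this position would read with a hydrogen, a fluoro, a bromo or a dimethylamino group, and so whether the step follows from chloro entering or from methoxy leaving.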